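The source may hold more compounds than are shown below. What is called first, only, known or untested is meant among the compounds shown, and "the series" means these compounds.

Measured compounds:
compound 1 `O=C(NC1CCCCC1)c1c(NO)cc(-c2ccccc2)oc1=O` gives 10500 nM
compound 2 `Cc1ccc(-c2cc(NO)c(C(=O)NC3CCCCC3)c(=O)o2)cc1` gives 10100 nM
compound 3 `O=C(Nc1ccccc1)c1c(NO)cc(-c2cccs2)oc1=O` gives > 20000 nM

The read-out throughout is an ADME assay on Huh-7 cells (Homo sapiens) for cytotoxicity, with a stated time of 3 days; on this read-out higher numbers stand for lower toxicity in this test and lower numbers for higher toxicity in this test. Compound 1 and compound 2 each give a number in this assay; for compound 3 the assay reports only a limit, (the limit of > 20000 nM in this assay, at which 1 of the 3 values shown sits), so where compound 3 truly stands is not known beyond that boundary.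

The unmeasured compound 4 `Cc1cccc(NC(=O)c2c(NO)cc(-c3cccs3)oc2=O)c1` is built from compound 3 by a single change: methyl in place of hydrogen on an aromatic carbon. For the measured compounds named here, the one measured step of the same kind is the one from compound 1 to compound 2, where the same methyl-for-hydrogen swap on an aromatic carbon gave a 1.0-fold lower number from compound 1 to compound 2 (0.02 log units; within the scatter). That precedent points to no movement beyond the usual scatter when a methyl is added this way, though it rests on one pair only and on a different ring of the molecule.

Compound 4 is therefore expected to stand essentially where compound 3 does, with the step that the limit leaves unreadable from compound 3 to compound 4 amounting to no real change. For compound 4 the estimate in this assay is 25000 nM, with a range from 12000 nM to 60000 nM, and it is expected that the assay will most likely again report only a limit rather than a number.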

Compound 4, half-maximal cytotoxic concentration: > 20000 nM
Compound 4: no number, only a limit; the forecaster's own chance of this, stated with the estimate: 75%; the middle value lies beyond the limit too.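

In this assay, compound 3 and compound 4 each give only a limit and not a number, so the step between them cannot be read: the limit of > 20000 nM in this assay, at which 2 of the 4 values shown sit.

The compounds shown leave open where compound 3 and compound 4 truly stand, and whether the change from phenyl to 3-methylphenyl alters the read-out at all.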